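The source may hold more compounds than are shown below. What is called first, only, known or untested is meant among the compounds shown, and "the series" means these compounds.

The compounds here share one core and differ in a single substituent on an aromatic carbon. In a functional assay on K562 cells (Homo sapiens) for inhibition, read by MTT assay (on this read-out higher numbers stand for weaker inhibition and lower numbers for stronger inhibition), compound 1 `C=C1C(=O)[C@@]23C(=O)OC[C@]4([C@@H](OC(C)=O)CCC(C)(C)[C@H]4C=O)[C@@H]2CC[C@H]1[C@H]3OC(=O)c1ccc(Cl)cc1`, the chloro member, gives 870 nM. Compound 2 `C=C1C(=O)[C@@]23C(=O)OC[C@]4([C@@H](OC(C)=O)CCC(C)(C)[C@H]4C=O)[C@@H]2CC[C@H]1[C@H]3OC(=O)c1ccc(OC)cc1`, the methoxy member, gives 1920 nM, and compound 3 `C=C1C(=O)[C@@]23C(=O)OC[C@]4([C@@H](OC(C)=O)CCC(C)(C)[C@H]4C=O)[C@@H]2CC[C@H]1[C@H]3OC(=O)c1ccc([N+](=O)[O-])cc1`, the nitro member, gives 1140 nM. Compound 3 stands within the scatter of both others, as shown by a 1.3-fold higher number from compound 1 to compound 3 (0.12 log units; within the scatter) and by a 1.7-fold lower number from compound 2 to compound 3 (0.23 log units; within the scatter). Among the measured compounds shown here, the only step beyond the scatter is a 2.2-fold higher number from compound 1 to compound 2 (0.34 log units; beyond the scatter), and it is modest.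

The next compound is compound 4 `C=C1C(=O)[C@@]23C(=O)OC[C@]4([C@@H](OC(C)=O)CCC(C)(C)[C@H]4C=O)[C@@H]2CC[C@H]1[C@H]3OC(=O)c1ccccc1`, which keeps the core but loses the substituent: hydrogen in place of nitro on an aromatic carbon, para to a large group. For the measured compounds named here, no measured compound carries hydrogen there, so no measured step covers this change directly. The closest evidence is the set of exchanges among chloro, methoxy and nitro. Two of these stay within the scatter, and the exception is the modest step between compound 1 and compound 2 noted above. On that basis, the expected result in this assay is a 1.1-fold higher number from compound 3 to compound 4 (0.06 log units; within the scatter), which means no step beyond the scatter is expected. For compound 4 the estimated value is 1300 nM, with an expected range from 650 nM to 2600 nM.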

Compound 4, half-maximal inhibitory concentration: 1400 nM
Beside the measured number, compound 4's estimate is 1.1-fold (0.03 log units) below it; low and high end bracket the measured number.
By their numbers in this assay, from the lowest: compounds 1, 3, 4 and 2 (each within the scatter of the next, the first and the last beyond it).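

With hydrogen on this aromatic carbon, para to a large group, the series now includes a member that carries no substituent there, and in this assay none of the three groups stands apart from it: removing nitro gives a 1.2-fold higher number from compound 3 to compound 4 (0.09 log units; within the scatter), hydrogen in place of methoxy gives a 1.4-fold lower number from compound 2 to compound 4 (0.14 log units; within the scatter), and hydrogen in place of chloro gives a 1.6-fold higher number from compound 1 to compound 4 (0.21 log units; within the scatter). Among the compounds shown here, a substituent at this position is therefore not needed for a value in this range, and compound 4 sits within the scatter of both ends of the only step beyond it, a 2.2-fold higher number from compound 1 to compound 2 (0.34 log units; beyond the scatter), so that modest step is a difference between chloro and methoxy rather than a gain or loss measured against hydrogen. Nothing offered here accounts for why the position tolerates these exchanges.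

An amine, a carboxylic acid or a longer alkyl chain on this carbon could still move the number beyond the scatter, and the compounds shown do not test any of them. They also leave open whether the same tolerance holds for a group placed elsewhere on the benzoyl ring, or in any cell line other than the one used here.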